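Swapping a Methylphenyl for a Difluorophenyl on the Sulfonyl

The source may report more compounds than this note shows. Statements on the series, on what has been measured and on what is new or still open speak of the compounds shown alone.

Compound 1 `CC1CCN(c2c(S(=O)(=O)c3ccccc3)cnc3cc(F)ccc23)CC1` carries a plain phenyl ring on its sulfonyl group, and in an assay on isolated protein for displacement of a labelled ligand from metabotropic glutamate receptor 5 (Homo sapiens), with a stated time of 60 min, tested at 1 uM (on this read-out higher numbers stand for more inhibition at the one concentration tested (going by the name of the read-out) and lower numbers for less inhibition), compound 1 gives 87%. Compound 2 `Cc1ccc(S(=O)(=O)c2cnc3cc(F)ccc3c2N2CCC(C)CC2)cc1` differs only by a methyl in place of hydrogen on an aromatic carbon, and in this assay compound 2 gives 88%. The step of a number 1 percentage points higher from compound 1 to compound 2 (within the scatter) shows that the two numbers sit within the scatter of each other, so the two numbers can only be called level.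

Compound 3 `CC1CCN(c2c(S(=O)(=O)c3cc(F)cc(F)c3)cnc3cc(F)ccc23)CC1` changes the same ring more deeply: 3,5-difluorophenyl in place of 4-methylphenyl on a sulfonyl sulfur. Going by the values given here, the only measured step touches this ring but is a different change, and it was within the scatter, so it gives little guidance. A step of modest size downward is expected, a number 8 percentage points lower from compound 2 to compound 3 (within the scatter), because the measured change at this ring gave a number 1 percentage points higher from compound 1 to compound 2 (within the scatter) and both values stayed high. Compound 3 is estimated at 80%, with a range from 55% to 95%.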

Compound 3, a percentage reported as inhibition, at one concentration (the size of the read-out at that concentration, not a potency): 77%
Compound 3: the middle estimate sits 3 percentage points above what was measured, and the stated range covers the measured number.
By their numbers in this assay, from the lowest: compounds 3, 1 and 2 (each within the scatter of the next, the first and the last beyond it).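

Going by these compounds alone, on a sulfonyl sulfur, 3,5-difluorophenyl in place of 4-methylphenyl gives a number 11 percentage points lower from compound 2 to compound 3 (beyond the scatter) in this assay, the only step in this small set to clear the scatter, so the group held at this position can alter the read-out. In place of the plain phenyl, the same group gives a number 10 percentage points lower from compound 1 to compound 3 (within the scatter) and stays inside the scatter, so only the comparison with 4-methylphenyl supports a real difference. Nothing available explains the difference seen with either change.

With the two fluorines always present together, these compounds cannot separate the contribution of each one. On these data alone, it also remains open how this position would respond to a ring bearing a methoxy group or a nitrile, or to a saturated ring such as cyclohexyl.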